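The compounds below may be only part of what the source reports. "The series", "measured", "known", "first", "only" and "open" are said of these compounds alone.

Measured so far in a functional assay on GBM1 cells (Homo sapiens) for antiproliferative activity, read by WST assay, with a stated time of 72 h; on this read-out higher numbers stand for weaker inhibition and lower numbers for stronger inhibition:
- Compound 1 `O=C(Nc1cc2ncncc2cc1OCc1ccc(F)cc1)Nc1cccc2ccccc12`: 8100 nM
- Compound 2 `O=C(Nc1ccccc1F)Nc1cc2ncncc2cc1OCc1ccccc1F`: 4200 nM

Only these two compounds have been measured. Within the data shown here, compound 1 at 8100 nM and compound 2 at 4200 nM lie within the usual scatter of each other, so the numbers do not separate them, and compound 1 stands level with the only other compound measured.

The next compound to be measured is compound 3 `O=C(Nc1cc2ncncc2cc1OCc1ccccc1Cl)Nc1cccc2ccccc12`. It keeps the core of compound 1 and carries 2-chlorophenyl in place of 4-fluorophenyl on a saturated chain carbon bound to an oxygen on an aromatic ring.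

Among the measured compounds shown here, no measured pair shows this change on its own, so the data give no direct precedent for it. For the measured compounds named here, the only guide is the close agreement of the two values already in hand. On that thin basis, the expected step of a 1.4-fold lower number from compound 1 to compound 3 (0.13 log units; within the scatter) is none beyond the scatter, with no firm direction. In this assay, compound 3 is estimated at 6000 nM, with an expected range of 2500 nM to 15000 nM.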

Compound 3, half-maximal inhibitory concentration: 2900 nM
For compound 3 the middle estimate is 2.1-fold (0.32 log units) above the measured one, within the range that was stated.
By their numbers in this assay, from the lowest: compounds 3, 2 and 1 (each within the scatter of the next, the first and the last beyond it).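

In this assay, among these compounds, putting 2-chlorophenyl in place of 4-fluorophenyl on a saturated chain carbon bound to an oxygen on an aromatic ring gives a 2.8-fold lower number from compound 1 to compound 3 (0.45 log units; beyond the scatter), a modest step and the only one so far between compounds that differ in one place. It shows that the read-out responds to this position: with the rest of compound 1 held fixed, this one exchange moves the number beyond the scatter, which the earlier pair, differing in more than one place, could not show. Nothing available bears on why this exchange has this effect.

The compounds shown leave open whether the step follows the chlorine or its place on the ring, since 4-fluorophenyl and 2-chlorophenyl differ in both, and 4-chlorophenyl or 2-fluorophenyl on the core of compound 1 would separate the two. Also open, as far as these compounds go, is how far the position tolerates something other than a halogen-bearing phenyl, such as a methoxy-bearing phenyl, an unsubstituted phenyl or a longer chain between the oxygen and the ring.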